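Moving the nitro group: from compound 3 to compound 4

The source may hold more compounds than are shown below. What is called first, only, known or untested is meant among the compounds shown, and "the series" means these compounds.

Measured so far:
- compound 1 `CCOC(=O)C1=C(Nc2ccccc2)S/C(=C\c2ccc[nH]2)C1=O`: 49.2%
- compound 2 `CCOC(=O)C1=C(Nc2ccccc2Br)S/C(=C\c2ccc[nH]2)C1=O`: 62.7%
- compound 3 `CCOC(=O)C1=C(Nc2ccc([N+](=O)[O-])cc2)S/C(=C\c2ccc[nH]2)C1=O`: 54.9%

These three share one core and differ only in the group on the amine nitrogen. In a functional assay on JAR cells (Homo sapiens) for inhibition, read by MTT assay, with a stated time of 72 h, tested at 10 uM (on this read-out lower numbers stand for less inhibition and higher numbers for more inhibition at the one concentration tested (going by the name of the read-out)), compound 3 stands second highest of the three numbers; its gap to compound 1, a number 5.7 percentage points higher from compound 1 to compound 3 (within the scatter) reversed in sense, and its gap to compound 2, a number 7.8 percentage points lower from compound 2 to compound 3 (within the scatter), both lie within the scatter. Compound 4 `CCOC(=O)C1=C(Nc2cccc([N+](=O)[O-])c2)S/C(=C\c2ccc[nH]2)C1=O` differs from compound 3 by 3-nitrophenyl in place of 4-nitrophenyl on an amine nitrogen. Among the measured compounds shown here, no measured step moves a group around the same ring, so the only guide is that every change on this ring so far stayed within the scatter of compound 3. The expected step is therefore none beyond the scatter, a number 2.1 percentage points higher from compound 3 to compound 4 (within the scatter). Compound 4 is estimated at 57%, between 42% and 72%.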

Compound 4, a percentage reported as inhibition, at one concentration (the size of the read-out at that concentration, not a potency): 57.4%
Compound 4: the middle estimate sits 0.4 percentage points below what was measured; the range from low to high includes it.
By their numbers in this assay, from the lowest: compounds 1, 3, 4 and 2 (each within the scatter of the next, the first and the last beyond it).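

In this assay, the 3-nitrophenyl and 4-nitrophenyl groups on the amine nitrogen cannot be told apart, with a number 2.5 percentage points higher from compound 3 to compound 4 (within the scatter) as the step between them. Compound 4 also stays within the scatter of both neighbours, with a number 8.2 percentage points higher from compound 1 to compound 4 (within the scatter) on one side and a number 5.3 percentage points lower from compound 2 to compound 4 (within the scatter) on the other, so it does not separate the unsubstituted phenyl from the 2-bromophenyl. Nothing available explains these numbers. On these data alone, whether an amine or a carboxylic acid in place of the nitro group would give a step beyond the scatter remains open.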